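This account rests on a few compounds, and the source may have more. Where it says the series, first, only, none or still open, it means among the compounds named here.

Working notes on the series, starting from compound 1 (`O=C(NCc1ccc(Cl)cc1)c1ncc2cccnc2c1O`). In a physicochemical assay for lipophilicity, at pH 7.4 (a higher number here means a more lipophilic compound, a lower number a more polar compound), compound 1 stands at "not determined" (no result reported) and so offers no number to start from. The entry for compound 2 (`Cc1n[nH]c(-c2ncc3c(N4CCCC4=O)ccnc3c2O)n1`) is no help either, since compound 2 also reads "not determined" (no result reported) in the same measurement. Only compound 3 (`O=C(NCc1ccc(Cl)cc1)c1ccc2cccnc2c1O`) carries a number in this assay, where compound 3 gives 4.8 as the sole reference point in the series. Going by the values given here, no measured pair differs in one place, so the data contain no step to read across.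

The next compound to be measured is compound 4 (`COc1ccc(CNC(=O)c2ncc3cccnc3c2O)cc1`). It keeps the core and the amide of compound 1 and carries methoxy in place of chloro on an aromatic carbon, para to a large group (methoxy in place of chloro on an aromatic carbon). Among the compounds with values here, with no measured step to lean on, the step expected in this assay for this change is a moderate one, downward and beyond the scatter, though this rests on judgement and not on data from the series. Within the data shown here, with compound 3 at 4.8 as the only number available, compound 4 is expected to fall well under that reference. Compound 4 is estimated at 2.6 within an expected range of 1.7 to 3.5 on this scale.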

Compound 4, distribution coefficient: 4.2
Compound 4: middle estimate off by 1.60 log units, on the low side, and the stated range ends below it.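

In this assay, going by these compounds alone, compound 4 gives 4.2 and compound 1 reads "not determined" (no result reported) with no new step to be read between them. No supporting evidence on this result is available.

The compounds shown leave open how far methoxy in place of chloro moves this reading on the shared core.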